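From trifluoromethoxy to bromo on a shared core

The compounds below may be only part of what the source reports. "The series", "measured", "known", "first", "only" and "open" are said of these compounds alone.

Compound 1 `CCOC(=O)c1c(-c2cccc(Br)c2)[nH]c2cc(OC)c(Cl)cc2c1=O` | > 21500 nM
Compound 2 `CCOC(=O)c1c(-c2cccc(OC(F)(F)F)c2)[nH]c2cc(OC)c(F)cc2c1=O` | > 21500 nM

Both entries come from an ADME assay on HepG2 cells (Homo sapiens) for cytotoxicity, read by luminescence, with a stated time of 72 h (on this read-out higher numbers stand for an effect only at larger amounts of compound and lower numbers for an effect already at smaller amounts), and neither of them is an exact number. The entry for compound 1, > 21500 nM, is a limit of the assay. The entry for compound 2, > 21500 nM, is also a limit, so compound 2 has no exact position on the scale. The two measured compounds therefore stand together: the limit of > 21500 nM in this assay, at which 2 of the 2 values shown sit.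

Compound 3 `CCOC(=O)c1c(-c2cccc(Br)c2)[nH]c2cc(OC)c(F)cc2c1=O` is compound 2 with bromo in place of trifluoromethoxy on an aromatic carbon, meta to a large group (bromo in place of trifluoromethoxy on an aromatic carbon). Within the data shown here, no measured pair shows what a single change of this kind does in this assay, so the expectation rests on the limit shared by the two measured compounds. No step beyond the usual scatter is expected, in either direction. The estimated step is a step that the limit leaves unreadable from compound 2 to compound 3. For compound 3 the expected value is 25000 nM, with an estimated range from 14000 nM to 45000 nM, and the assay will probably report only a limit again.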

Compound 3, half-maximal effective concentration: > 21500 nM
Compound 3: no number, only a limit (the forecaster's own chance of this, stated with the estimate: 85%); the middle value does not contradict the limit.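

In this assay, no size can be read for the change from compound 2 to compound 3 or from compound 1 to compound 3, and all three compounds stand at one shared limit: the limit of > 21500 nM in this assay, at which 3 of the 3 values shown sit. The compounds shown leave open where each one's true value lies, and whether either single change shifts it at all.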